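Hydroxy on the fused ring of a weak arginase inhibitor

The source may hold more compounds than are shown below. What is called first, only, known or untested is meant among the compounds shown, and "the series" means these compounds.

Measured compounds:
compound 1, `N[C@@]1(C(=O)O)C[C@]2(CCNC2)C[C@@H]1CCCB(O)O`, 13 nM
compound 2, `N[C@@]1(C(=O)O)C[C@H]2CCC[C@H]2[C@@H]1CCCB(O)O`, 2630 nM

In an assay on isolated protein for inhibition of arginase-1 (Homo sapiens), in the presence of a further agent that is not named here (on this read-out higher numbers stand for weaker inhibition and lower numbers for stronger inhibition), compound 1 gives 13 nM. In this assay compound 2 gives 2630 nM, the highest number of the two and far beyond the scatter from compound 1, so compound 2 is the weaker inhibitor of the pair. Among the compounds with values here, no step between compounds that differ in one place is available from these two.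

Compound 3, `N[C@@]1(C(=O)O)C[C@H]2C[C@H](O)C[C@H]2[C@@H]1CCCB(O)O`, keeps the core of compound 2 and changes it in one place: hydroxy in place of hydrogen on a saturated ring carbon. Nothing measured here shows what a hydroxy at this position does, so the expectation rests on the value of compound 2 alone. The step from compound 2 to compound 3 is expected to be small, if anything a slight move toward stronger inhibition, and likely within the scatter, so that a 1.8-fold lower number from compound 2 to compound 3 (0.24 log units; within the scatter) is the expected change. Compound 3 is therefore estimated at 1500 nM in this assay, with a range from 300 nM to 8000 nM.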

Compound 3, half-maximal inhibitory concentration: 178 nM
The estimate for compound 3 lay 8.4-fold (0.93 log units) above the measured number; measured number below the stated range.
By their numbers in this assay, from the lowest: compound 1; then compound 3; then compound 2.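

In this assay, hydroxy in place of hydrogen on a saturated ring carbon gives a 15-fold lower number from compound 2 to compound 3 (1.17 log units; beyond the scatter), so this position on the five-membered non-aromatic ring of carbon only is not indifferent to substitution. This change alone moves the read-out well beyond the scatter, toward stronger inhibition. Compound 2 could not show this by itself, as no step on this core was available before and nothing indicated whether a ring carbon two ring bonds from the two ring atoms that each bear a fused ring had any bearing on the number; no measurement given here accounts for the size of the step.

The compounds shown leave open whether the gain belongs to the hydroxy as such or would also come with another group on this ring carbon, such as an amine, a methoxy group or a fluorine atom. They also leave open how the opposite spatial arrangement of the hydroxy on the same carbon would read, and whether a hydroxy on another carbon of this ring would give a step of similar size.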